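Methylating the Urea Terminus of a Sulfonamide Oxadiazole

The compounds below may be only part of what the source reports. "The series", "measured", "known", "first", "only" and "open" are said of these compounds alone.

Compound 1 `CC(=O)Nc1ccc(S(=O)(=O)Nc2cccc(-c3nc(-c4ccc(NC(=O)c5cccnc5)cc4Cl)no3)c2)cc1Cl`: in a functional assay on MDA-MB-231 cells (Homo sapiens) for antiproliferative activity, read by MTT assay, with a stated time of 72 h (a higher number here means a weaker inhibitor, a lower number a stronger inhibitor), compound 1 reaches only the assay limit, > 10000 nM.
Compound 2 `NC(=O)Nc1ccc(S(=O)(=O)Nc2cccc(-c3nc(-c4ccc(NC(=O)c5cccnc5)cc4Cl)no3)c2)cc1`: in this assay compound 2 gives 2800 nM.

Compound 2 thus holds the only real number shown, the other value being a limit (the limit of > 10000 nM in this assay, at which 1 of the 2 values shown sits). Compound 3 `CNC(=O)Nc1ccc(S(=O)(=O)Nc2cccc(-c3nc(-c4ccc(NC(=O)c5cccnc5)cc4Cl)no3)c2)cc1` differs from compound 2 by methyl in place of hydrogen on an amide-type nitrogen. Going by the values given here, the one measured step, an at least 3.5-fold lower number from compound 1 to compound 2 (0.55 log units; beyond the scatter), alters the group on the sulfonyl sulfur, not the ureido nitrogen changed here, so it offers no direct guide. No step beyond the scatter is therefore expected. Compound 3 is estimated at 3000 nM, between 1000 nM and 9000 nM. The expected step is a 1.1-fold higher number from compound 2 to compound 3 (0.03 log units; within the scatter), within the scatter.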

Compound 3, half-maximal inhibitory concentration: 1300 nM
The estimate for compound 3 lay 2.3-fold (0.36 log units) above the measured number; low and high end bracket the measured number.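

In this assay, going by these compounds alone, the ureido terminus proves sensitive to substitution: methyl in place of hydrogen on this amide-type nitrogen gives a 2.2-fold lower number from compound 2 to compound 3 (0.33 log units; beyond the scatter), the first direct reading at this nitrogen. Set against the 4-acetamido-3-chlorophenyl group on the sulfonyl sulfur, the 4-((methylcarbamoyl)amino)phenyl group gives an at least 7.6-fold lower number from compound 1 to compound 3 (0.88 log units; beyond the scatter). The value of compound 1 is a limit, not a number: the limit of > 10000 nM in this assay, at which 1 of the 3 values shown sits.

The compounds shown leave open whether ethyl, a longer chain or a second methyl on this nitrogen would lower the number further or raise it again.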